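Aryl amide swap on the dihydro core: compound 4

The source may report more compounds than this note shows. Statements on the series, on what has been measured and on what is new or still open speak of the compounds shown alone.

Measured compounds in an assay on HEK293 cells for agonist activity at Bile acid receptor (Homo sapiens), read by a luciferase reporter; a higher number here means that more compound is needed for the effect, a lower number that less compound is needed:
- compound 1 `CC(C)OC(=O)C1=CN(C(=O)c2ccc(C#N)cc2)CC(C)(C)c2cc(C#N)[nH]c21` gives 35 nM
- compound 2 `CC(C)OC(=O)C1CN(C(=O)c2cccc(Cl)c2)CC(C)(C)c2cc(C#N)[nH]c21` gives 1300 nM
- compound 3 `CC(C)OC(=O)C1CN(C(=O)c2ccc(Cl)cc2)CC(C)(C)c2cc(C#N)[nH]c21` gives 4100 nM

Compound 1 stands lowest of the three numbers; compound 2 is nearest to it and compound 3 furthest, both beyond the scatter. Compounds 2 and 3 share a saturated core position that compound 1 lacks, so the gap to compound 1 cannot be assigned to the aryl group alone.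

Compound 4 `CC(C)OC(=O)C1=CN(C(=O)c2cccc(C(F)(F)F)c2)CC(C)(C)c2cc(C#N)[nH]c21` differs from compound 1 in one place: 3-(trifluoromethyl)phenyl in place of 4-cyanophenyl on a carbonyl carbon. Going by the values given here, the only measured step touching the aryl amide is a 3.2-fold higher number from compound 2 to compound 3 (0.50 log units; beyond the scatter), which moves a chloro substituent between ring positions on the saturated core. It points, if anything, to a 3-substituted phenyl giving a lower number than a 4-substituted one, but neither the substituent nor the core matches compound 4, so its weight is limited. Nothing measured speaks to a trifluoromethyl or to loss of the nitrile acceptor.

On that basis the step in this assay is expected to be small, a 1.2-fold lower number from compound 1 to compound 4 (0.07 log units; within the scatter), around no change beyond the scatter with the wider uncertainty allowed on the side of a lower number. Compound 4 is therefore estimated at 30 nM, with a range of 8 nM to 150 nM.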

Compound 4, half-maximal effective concentration: 8.5 nM
Beside the measured number, compound 4's estimate is 3.5-fold (0.55 log units) above it; measured number inside the range.
By their numbers in this assay, from the lowest: compound 4; then compound 1; then compound 2; then compound 3.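

In this assay, going by these compounds alone, the step of a 4.1-fold lower number from compound 1 to compound 4 (0.61 log units; beyond the scatter) is the first measured change of the aryl amide on the core of compound 1, and it shows that this place tolerates more than the 4-cyanophenyl group. The 4-cyanophenyl group is not needed for a low number here: compound 4 carries 3-(trifluoromethyl)phenyl on the same carbonyl carbon, with no nitrile and 0 hydrogen-bond acceptors in the entering group, and its number is lower beyond the scatter, whereas the earlier step of a 3.2-fold higher number from compound 2 to compound 3 (0.50 log units; beyond the scatter) concerned only a chloro group on a different core. The change replaces the substituent and its ring position together, so the step cannot be assigned to either one alone, and no supporting measurement is available to explain it.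

Still open, from the compounds shown here alone, is how 4-(trifluoromethyl)phenyl or 3-cyanophenyl would read on the core of compound 1, as either one would separate the substituent from its ring position. Also open, going by these compounds, is whether this place accepts a quite different group on the carbonyl carbon, such as a phenyl ring bearing a carboxylic acid or an amine.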